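This account rests on a few compounds, and the source may have more. Where it says the series, first, only, none or still open, it means among the compounds named here.

Compound 1 `COc1ccc(C(=O)/C=C/c2cc3ccccc3[nH]c2=O)cc1` and compound 2 `O=C(/C=C/c1cc2ccccc2[nH]c1=O)c1ccc(O)cc1` share one core, and in an ADME assay on CAKI-1 cells (Homo sapiens) for cytotoxicity, read by sulforhodamine B assay, with a stated time of 24 h (on this read-out lower numbers stand for higher toxicity in this test and higher numbers for lower toxicity in this test), compound 1 gives 6900 nM. Compound 2 reaches only > 100000 nM in this assay, which is a limit of the assay rather than a number. The change from hydrogen in place of methyl on an oxygen on an aromatic ring brought an at least 14-fold higher number from compound 1 to compound 2 (1.16 log units; beyond the scatter), with one value sitting at the limit of > 100000 nM in this assay, at which 1 of the 2 values shown sits. Compound 3 `O=C(/C=C/c1cc2ccccc2[nH]c1=O)c1ccc(Cl)cc1` carries the change (chloro in place of hydroxy on an aromatic carbon). Among the measured compounds shown here, only that one measured step bears on it, and it was large, so a large step back toward compound 1 is expected, an at least 10-fold lower number from compound 2 to compound 3 (1.00 log units; beyond the scatter). Compound 3 is therefore estimated at 10000 nM, between 3000 nM and 60000 nM.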

Compound 3, concentration lethal to 50% of the cells: 6800 nM
Estimate against measurement, compound 3: 1.5-fold (0.17 log units) above; the measured number falls inside the stated range.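

The new compound shows that the methyl on the oxygen is not specifically needed to keep the lower number, since chloro serves equally well on this aromatic carbon: a 1.0-fold lower number from compound 1 to compound 3 (0.01 log units; within the scatter). In this assay, among the compounds shown here, hydroxy is thus the one group of the three that stands apart, with chloro undoing the earlier change by an at least 14-fold lower number from compound 2 to compound 3 (1.16 log units; beyond the scatter). The size of this step rests on a limit of the assay for compound 2, not on a number: the limit of > 100000 nM in this assay, at which 1 of the 3 values shown sits.

On these data alone, whether an amine or a carboxylic acid on this carbon would read like hydroxy or like chloro and methoxy stays open. So does the true distance of compound 2 from the other two compounds.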